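The compounds below may be only part of what the source reports. "The series", "measured", "known", "first", "only" and "open" are said of these compounds alone.

Measured compounds:
compound 1 `C=CCN(C)C(=O)c1ccc(C(CC)(CC)c2ccc(OCCC(O)(CC)CC)c(C)c2)n1CC` — > 10000 nM
compound 2 `CCC(C)C(NC(=O)c1ccc(C(CC)(CC)c2ccc(OCCC(O)(CC)CC)c(C)c2)n1CC)C(=O)OC` — > 10000 nM

In an assay on cells for agonist activity at vitamin D3 receptor (Homo sapiens), with a stated time of 96 h (on this read-out lower numbers stand for an effect already at smaller amounts and higher numbers for an effect only at larger amounts of compound), compound 1 gives > 10000 nM, which is a limit of the assay and not a number. Compound 2 likewise gives > 10000 nM, again a limit. The step that the two limits leave unreadable from compound 1 to compound 2 is therefore unreadable, as both values sit at the limit of > 10000 nM in this assay, at which 2 of the 2 values shown sit. Compound 3 `CCC(C)C(CO)NC(=O)c1ccc(C(CC)(CC)c2ccc(OCCC(O)(CC)CC)c(C)c2)n1CC` differs from compound 1 by (1-(hydroxymethyl)-2-methylbutyl)amino in place of allyl(methyl)amino on a carbonyl carbon. For the measured compounds named here, the single measured step also changes the group on the carbonyl carbon and stays at the limit, so no size or direction can be drawn from it. Compound 3 is expected to stay at the limit too, estimated at 20000 nM with a range from 5000 nM to 100000 nM. For compound 3 the expected step is a step that the limit leaves unreadable from compound 1 to compound 3.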

Compound 3, half-maximal effective concentration: 450 nM
The estimate for compound 3 lay 44-fold (1.65 log units) above the measured number; the whole stated range lies above it.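

In this assay, the group on the carbonyl carbon can bring this series from a limit to a readable number: (1-(hydroxymethyl)-2-methylbutyl)amino in place of allyl(methyl)amino gives an at least 22-fold lower number from compound 1 to compound 3 (1.34 log units; beyond the scatter). Within that side chain, hydroxymethyl in place of methoxycarbonyl gives an at least 22-fold lower number from compound 2 to compound 3 (1.34 log units; beyond the scatter). Both steps start from a limit, so their true size stays open: the limit of > 10000 nM in this assay, at which 2 of the 3 values shown sit.

The compounds shown leave open whether a carboxylic acid or an amine in place of the hydroxymethyl, or a longer chain in place of the 2-methylbutyl part, would keep this number.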